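A carbon-only ring in place of pyridin-3-yl

The compounds below may be only part of what the source reports. "The series", "measured", "known", "first", "only" and "open" are said of these compounds alone.

Compound 1 `COc1ccc(-c2c(C)nn(-c3nc(-c4ccc(Cl)c(Cl)c4)c(SC(C)C)s3)c2C(=O)O)cc1` and compound 2 `Cc1nn(-c2nc(-c3ccc(Cl)c(Cl)c3)c(SC(C)C)s2)c(C(=O)O)c1-c1cccnc1` share one core and differ only in the aromatic group placed next to the carboxy group. In a functional assay on BJAB cells (Homo sapiens) for antiproliferative activity, with a stated time of 4 days (a lower number here means that less compound is needed, a higher number that more compound is needed for the effect), compound 1 gives 2100 nM, and in this assay compound 2 gives 12000 nM. The step is a 5.7-fold higher number from compound 1 to compound 2 (0.76 log units; beyond the scatter), so compound 2 stands with the higher of the two numbers, and the gap to compound 1 lies beyond the scatter.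

Compound 3 `Cc1nn(-c2nc(-c3ccc(Cl)c(Cl)c3)c(SC(C)C)s2)c(C(=O)O)c1-c1ccccc1[N+](=O)[O-]` carries the change (2-nitrophenyl in place of pyridin-3-yl on an aromatic carbon). Among the measured compounds shown here, only the single step between compound 1 and compound 2 bears on this, and only indirectly: it shows that exchanging pyridin-3-yl for a carbon-only aromatic ring, there 4-methoxyphenyl, went together with a lower number in this assay because of a 5.7-fold higher number from compound 1 to compound 2 (0.76 log units; beyond the scatter). Since 2-nitrophenyl is not 4-methoxyphenyl, that step is taken as a hint rather than a measure.

Compound 3 is therefore expected to give a modestly lower number than compound 2 in this assay, with an expected step of a 2.7-fold lower number from compound 2 to compound 3 (0.43 log units; beyond the scatter). The estimate for compound 3 in this assay is 4500 nM, within a range from 1500 nM to 14000 nM.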

Compound 3, half-maximal effective concentration: 4700 nM
For compound 3 the middle estimate is 1.0-fold (0.02 log units) below the measured one; measured number inside the range.
By their numbers in this assay, from the lowest: compound 1; then compound 3; then compound 2.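

With a 2.6-fold lower number from compound 2 to compound 3 (0.41 log units; beyond the scatter), a second carbon-only ring joins 4-methoxyphenyl in giving a lower number than pyridin-3-yl in this assay, so among these three compounds the direction no longer rests on a single pair, and none of them goes against it. The two carbon-only rings do not give the same number, however: a 2.2-fold higher number from compound 1 to compound 3 (0.35 log units; beyond the scatter) shows that at this position, on the aromatic carbon next to the ring atom that bears the carboxy group, the outcome depends on more than whether the ring holds a nitrogen. The two rings differ both in the group they carry and in where it sits, and nothing available here explains the differences among the three numbers.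

The compounds shown leave open how much of the step between compound 1 and compound 3 belongs to the group and how much to its place on the ring, which 2-methoxyphenyl or 4-nitrophenyl would help to separate. They also leave open where an unsubstituted phenyl ring or a 2-aminophenyl group would fall relative to these three compounds.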